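Fluoro in place of sulfamoyl on an aziridine urea

A few compounds are considered here, and "the series" means these few. Any claim that something is new, unique, unknown or untested is made for them only; others in the source may bear on it.

Compound 1, `N#CC1CN1C(=O)NCc1ccccc1`: 5300 nM
Compound 2, `N#CC1CN1C(=O)Nc1ccc(S(N)(=O)=O)cc1`: > 38000 nM

In a functional assay on WiDr cells (Homo sapiens) for inhibition (a lower number here means a stronger inhibitor, a higher number a weaker inhibitor), compound 1 gives 5300 nM. Compound 2 reaches only the limit of the assay, > 38000 nM, so no number is known for it; this is the limit of > 38000 nM in this assay, at which 1 of the 2 values shown sits. Compound 3 is `N#CC1CN1C(=O)Nc1ccc(F)cc1`, and it differs from compound 2 by fluoro in place of sulfamoyl on an aromatic carbon. With compound 2 fixed only by a limit, the step from compound 2 to compound 3 in this assay cannot be sized from the data. Compound 3 is expected to give about 20000 nM, between 5000 nM and 80000 nM, the estimated step being an at least 1.9-fold lower number from compound 2 to compound 3 (0.27 log units; that floor lies within the scatter).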

Compound 3, half-maximal inhibitory concentration: 2100 nM
For compound 3 the middle estimate is 9.5-fold (0.98 log units) above the measured one; measured number below the stated range.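

Among the compounds shown here, at this aromatic carbon, fluoro in place of sulfamoyl gives an at least 18-fold lower number from compound 2 to compound 3 (1.25 log units; beyond the scatter) in this assay, so the group on this position matters, which the earlier compounds could not show. Compound 2 stands at a limit of the assay and not at a number, so this step is a floor only: the limit of > 38000 nM in this assay, at which 1 of the 3 values shown sits.

The compounds shown leave open whether the loss of sulfamoyl or the arrival of fluoro carries the step. As far as these compounds go, how chloro, methoxy or an amine on this carbon would compare also stays open.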